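A second methyl on the amine nitrogen

This account rests on a few compounds, and the source may have more. Where it says the series, first, only, none or still open, it means among the compounds named here.

Compound 3 `CNCc1ccc(-n2c(SC(C)c3ccccc3)nc3c(cnn3C)c2=O)cc1` gives the highest of the three numbers in an assay on isolated protein for inhibition of Retinaldehyde dehydrogenase 3 (Homo sapiens), tested at 5 uM (on this read-out higher numbers stand for more inhibition at the one concentration tested (going by the name of the read-out) and lower numbers for less inhibition), at 57%, though compound 1 `CC(Sc1nc2c(cnn2C)c(=O)n1-c1ccc(CN)cc1)c1ccccc1`, at 56%, lies within the scatter of it. Compound 2 `COCCc1ccc(-n2c(SC(C)c3ccccc3)nc3c(cnn3C)c2=O)cc1` gives 34%. The step of a number 1 percentage points higher from compound 1 to compound 3 (within the scatter) shows that one methyl on the amine nitrogen made no difference beyond the scatter, whereas a number 22 percentage points lower from compound 1 to compound 2 (beyond the scatter) and a number 23 percentage points higher from compound 2 to compound 3 (beyond the scatter) show that trading the amine for methoxymethyl costs a modest amount. Compound 4 `CC(Sc1nc2c(cnn2C)c(=O)n1-c1ccc(CN(C)C)cc1)c1ccccc1` differs from compound 3 by methyl in place of hydrogen on an amine nitrogen. Because the first methyl on that nitrogen gave a number 1 percentage points higher from compound 1 to compound 3 (within the scatter), the second is expected to change little, and the expected step is a number 2 percentage points lower from compound 3 to compound 4 (within the scatter). Compound 4 is therefore estimated at 55%, within a range of 40% to 70%.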

Compound 4, a percentage reported as inhibition, at one concentration (the size of the read-out at that concentration, not a potency): 53%
For compound 4 the middle estimate is 2 percentage points above the measured one; the range from low to high includes it.
By their numbers in this assay, from the lowest: compound 2; then compounds 4, 1 and 3 (each within the scatter of the next).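

In this assay, taking the last hydrogen off the amine nitrogen leaves the number within the scatter (a number 4 percentage points lower from compound 3 to compound 4 (within the scatter)), and the full change from amino to dimethylamino does the same (a number 3 percentage points lower from compound 1 to compound 4 (within the scatter)). So among these compounds a hydrogen on that nitrogen is not needed to keep the number, and dimethylamino keeps the gap to methoxymethyl (a number 19 percentage points higher from compound 2 to compound 4 (beyond the scatter)). No measurement here accounts for these numbers. From the compounds shown here alone, it remains open whether an ethyl group on that nitrogen, or a carboxylic acid in place of the amine, would hold the number.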